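The source may report more compounds than this note shows. Statements on the series, on what has been measured and on what is new or still open speak of the compounds shown alone.

- compound 1 `CCn1c(C(=O)N(C)CCC#N)ccc1C(CC)(CC)c1ccc(OCC(O)C(C)(C)C)c(C)c1`: > 50000 nM, a limit of the assay and not a number
- compound 2 `CCn1c(C(=O)N(CCC#N)CCC#N)ccc1C(CC)(CC)c1ccc(OCC(O)C(C)(C)C)c(C)c1`: 7100 nM

For the measured compounds named here, in a functional assay on Caco-2 cells (Homo sapiens), read by MTT assay, with a stated time of 48 h (on this read-out lower numbers stand for stronger inhibition and higher numbers for weaker inhibition), compound 2 gives 7100 nM, the only actual number so far. The sole other result is a limit, held by compound 1 (the limit of > 50000 nM in this assay, at which 1 of the 2 values shown sits). Compound 3 `C#CC(C)OC(=O)c1ccc(C(CC)(CC)c2ccc(OCC(O)C(C)(C)C)c(C)c2)n1CC` has not yet been measured. Its structural change is a group of 5 heavy atoms (4 carbon, 1 oxygen; no ring) in place of a group of 9 heavy atoms (6 carbon, 3 nitrogen; no ring), on a carbonyl carbon, so a group of 5 heavy atoms replaces one of 9 on a carbonyl carbon. Going by the values given here, one measured step bears on this, an at least 7.0-fold lower number from compound 1 to compound 2 (0.84 log units; beyond the scatter), and it altered the same group that now leaves. Among the compounds with values here, that step shows only that the group's make-up can matter, and no measured step covers the entering group. A modest move towards weaker inhibition is therefore expected, with wide uncertainty. The estimated change is a 2.0-fold higher number from compound 2 to compound 3 (0.29 log units; within the scatter). For compound 3 the expected value is 14000 nM, with an estimated range from 3500 nM to 50000 nM.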

Compound 3, half-maximal inhibitory concentration: > 50000 nM
Compound 3 ended at the assay's limit; the forecaster's own chance of this, stated with the estimate: 25%; at least 3.5-fold (0.55 log units) between middle value and limit.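

Earlier, only the make-up of the group on the carbonyl carbon had been varied. Now, in this assay, (1-methylprop-2-yn-1-yl)oxy in place of the group of 9 heavy atoms gives an at least 7.0-fold higher number from compound 2 to compound 3 (0.84 log units; beyond the scatter), so the entering group does not keep the measurable inhibition of compound 2. For compound 3, > 50000 nM is a limit of the assay and not a number. The step from compound 1 to compound 3 cannot be read: the limit of > 50000 nM in this assay, at which 2 of the 3 values shown sit.

The compounds shown leave open how far compound 1 and compound 3 lie from that limit, and so which of the two groups is the weaker. They also leave open whether a different group on the carbonyl carbon, such as dimethylamino or a longer chain bearing a nitrile, would give an actual number.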